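The compounds below may be only part of what the source reports. "The series", "measured", "known", "first", "only" and "open" are said of these compounds alone.

Measured so far:
- compound 1 `O=C(CSc1ncccn1)N/N=c1/scc(-c2ccc(F)cc2)n1-c1ccccc1`: in an ADME assay on NIH3T3 cells (Mus musculus) for cytotoxicity, read by MTT assay, with a stated time of 24 h (on this read-out lower numbers stand for stronger inhibition and higher numbers for weaker inhibition), compound 1 gives > 500 ug/mL, a limit of the assay rather than a number.
- compound 2 `Cc1nnc(SCC(=O)N/N=c2/scc(-c3ccc(F)cc3)n2-c2ccccc2)s1`: in this assay compound 2 gives 383 ug/mL.

Compound 1 therefore stands only at the assay limit, the position described by the limit of > 500 ug/mL in this assay, at which 1 of the 2 values shown sits; no number is known for it. For the measured compounds named here, the one measured step, an at least 1.3-fold lower number from compound 1 to compound 2 (0.11 log units; that floor lies within the scatter), concerns a different part of the molecule, 5-methyl-1,3,4-thiadiazol-2-yl in place of pyrimidin-2-yl on a sulfur, and its floor lies within the scatter.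

Compound 3 `N#Cc1ccc(-c2cs/c(=N/NC(=O)CSc3ncccn3)n2-c2ccccc2)cc1` differs from compound 1 by cyano in place of fluoro on an aromatic carbon; cut one bond further out the same difference reads 4-fluorophenyl to 4-cyanophenyl. Going by the values given here, no measured step touches this position, so nothing among the measured compounds points to a shift in this assay in either direction beyond the scatter, and the likeliest outcome is again a reading at or near the limit.

For compound 3 the expected value in this assay is 500 ug/mL, with a range from 250 ug/mL to 1500 ug/mL, which means an expected step of a number no higher from compound 1 to compound 3 (the limit leaves the size open).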

Compound 3, half-maximal inhibitory concentration: < 3.9 ug/mL
Compound 3: a limit, no number; the forecaster's own chance of this, stated with the estimate: 60%; at least 120-fold (2.10 log units) between middle value and limit.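

In this assay, the position on the six-membered aromatic ring of carbon only, para to a large group, proves highly sensitive: cyano in place of fluoro on an aromatic carbon gives an at least 120-fold lower number from compound 1 to compound 3 (2.10 log units; beyond the scatter). For the compounds shown here, the only earlier step, an at least 1.3-fold lower number from compound 1 to compound 2 (0.11 log units; that floor lies within the scatter), concerned the group on the sulfur and gave no change that could be told from the scatter, so this is the first step to clear it, and it comes from a change of only a few atoms at a different place in the molecule. The reading for compound 3 is a limit of the assay, not a number: the limit of < 3.9 ug/mL in this assay, at which 1 of the 3 values shown sits.

From the compounds shown here alone, the size of the step remains open at both ends, since neither compound 1 nor compound 3 has a number, and it is also open whether the change carries over to the series with 5-methyl-1,3,4-thiadiazol-2-yl on the sulfur, as in compound 2. The compounds shown also leave open whether this steep drop is particular to cyano or also appears with an amine, a carboxylic acid or a methoxy group at the same position.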